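Methoxy for Chloro on a Second Halogenated Core

The source may report more compounds than this note shows. Statements on the series, on what has been measured and on what is new or still open speak of the compounds shown alone.

Measured so far:
compound 1 `CC(Br)C(=O)Nc1cc(C(=O)NC(N)=O)ccc1Cl` gives 9800 nM;
compound 2 `COc1ccc(C(=O)NC(N)=O)cc1NC(=O)C(C)Br` gives > 20000 nM, which is a limit of the assay and not a number;
compound 3 `CC(Cl)C(=O)Nc1cc(C(=O)NC(N)=O)ccc1Cl` gives > 20000 nM, likewise a limit of the assay.

All three were tested in a functional assay on CCRF-CEM cells (Homo sapiens) for antiproliferative activity, read by trypan blue exclusion, with a stated time of 72 h; a lower number here means a stronger inhibitor, a higher number a weaker inhibitor. Among the compounds with values here, compound 1 is the only one with a numeric value. Its two neighbours sit at the limit of > 20000 nM in this assay, at which 2 of the 3 values shown sit, so each step from it can only be given as a floor: an at least 2.0-fold higher number from compound 1 to compound 2 (0.30 log units; that floor lies within the scatter) and an at least 2.0-fold higher number from compound 1 to compound 3 (0.30 log units; that floor lies within the scatter).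

The first of those steps is the change (methoxy in place of chloro on an aromatic carbon). The two cores differ by chloro in place of bromo on a saturated chain carbon bound to a carbonyl carbon and a saturated chain carbon. Compound 4 `COc1ccc(C(=O)NC(N)=O)cc1NC(=O)C(C)Cl`, not yet measured in this assay, carries that same change onto the core of compound 3: methoxy in place of chloro on an aromatic carbon. Around the place the two changes differ only in that it sits ortho to a ((1-bromoethyl)carbonyl)amino group in compound 1 and ortho to a ((1-chloroethyl)carbonyl)amino group in compound 3, so they are the same kind of change, not the same.

Compound 3 already sits at the limit, and the step from compound 1 to compound 2 was at least a weakening, so compound 4 is expected to stay at or beyond that limit, an expected step that the limit leaves unreadable from compound 3 to compound 4. The estimate for compound 4 is 35000 nM, within 15000 nM to 120000 nM.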

Compound 4, half-maximal inhibitory concentration: > 20000 nM
Compound 4 was reported as a limit; the forecaster's own chance of this, stated with the estimate: 90%; the middle value lies beyond the limit too.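

In this assay compound 4 gives > 20000 nM, which is a limit of the assay and not a number. No step from compound 2 or compound 3 to compound 4 can be read, because all three stop at the same limit: the limit of > 20000 nM in this assay, at which 3 of the 4 values shown sit.

The compounds shown leave open how far compound 2, compound 3 and compound 4 differ from one another, if they differ at all.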